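Replacing the Urea Link with an Amide

A few compounds are considered here, and "the series" means these few. Any claim that something is new, unique, unknown or untested is made for them only; others in the source may bear on it.

Of the compounds shown here, three share a common core and have been measured. Compound 2 `COc1cc(-c2nn(-c3cccc(NC(=O)Nc4ccc(Cl)c(Cl)c4)c3)cc2-c2ccncc2)ccc1Cl` is the point of departure. In a functional assay on SK-MEL-28 cells (Homo sapiens) for inhibition, read by sulforhodamine B assay, with a stated time of 48 h (a lower number here means a stronger inhibitor of growth, a higher number a weaker inhibitor of growth), compound 2 gives 1430 nM. Compound 1 `COc1cc(-c2nn(-c3cccc(NC(=O)Nc4cc(C(F)(F)F)cc(C(F)(F)F)c4)c3)cc2-c2ccncc2)ccc1Cl` gives 851 nM, and compound 3 `O=C(Nc1cccc(-n2cc(-c3ccncc3)c(-c3ccc(Cl)c(O)c3)n2)c1)Nc1ccc(Cl)c(Cl)c1` gives 1460 nM. Within the data shown here, compound 2 thus holds the second highest of the three numbers, and both of its neighbours sit within the scatter of it: the one measured step, hydrogen in place of methyl on an oxygen on an aromatic ring, runs from compound 2 to compound 3 and gives a 1.0-fold higher number from compound 2 to compound 3 (0.01 log units; within the scatter), while the values of compound 1 and compound 2 also lie within the scatter of each other.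

Compound 4 `COc1cc(-c2nn(-c3cccc(NC(=O)c4ccc(Cl)c(C(F)(F)F)c4)c3)cc2-c2ccncc2)ccc1Cl` differs from compound 2 in one place: 4-chloro-3-(trifluoromethyl)phenyl in place of (3,4-dichlorophenyl)amino on a carbonyl carbon. In plain words, the urea link becomes an amide, and the outer ring carries a different pair of substituents. Among the measured compounds shown here, no measured step touches this kind of change; the only step available alters a distant part of the molecule and itself lies within the scatter. With nothing pointing in either direction, the step from compound 2 to compound 4 is expected to be a 1.1-fold higher number from compound 2 to compound 4 (0.05 log units; within the scatter), that is, no change beyond the scatter, though with wide uncertainty. Compound 4 is therefore estimated at 1600 nM, with a range from 500 nM to 5000 nM.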

Compound 4, concentration for 50% growth inhibition: 3080 nM
Compound 4: middle estimate off by 1.9-fold (0.28 log units), on the low side; measured number inside the range.
By their numbers in this assay, from the lowest: compounds 1, 2 and 3 (each within the scatter of the next); then compound 4.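

In this assay, among these compounds, the change on the carbonyl carbon gives a 2.2-fold higher number from compound 2 to compound 4 (0.33 log units; beyond the scatter), a modest shift but the only step in this set that lies beyond the scatter, so this site responds to change in a way that the swap of hydrogen for methyl on the aromatic oxygen did not. The step cannot be split into separate effects, however: it removes (3,4-dichlorophenyl)amino, with the urea nitrogen that links the outer ring to the carbonyl, and also changes the substituents on that ring by bringing in 4-chloro-3-(trifluoromethyl)phenyl. No outside evidence is available here to explain why the number rises.

The compounds shown leave open which part of this double change carries the shift, a question that an amide with a 3,4-dichlorophenyl ring or a urea with a 4-chloro-3-(trifluoromethyl)phenyl ring could answer. They also leave open how the number would respond to something quite different on the carbonyl carbon, such as a simple alkyl chain in place of the outer aromatic ring.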